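Swapping 3-aminophenyl for 4-fluorophenyl on the shared core

This account rests on a few compounds, and the source may have more. Where it says the series, first, only, none or still open, it means among the compounds named here.

- Compound 1 `COc1cc(-n2cnc3ccc(-c4ccc(C(C)=O)cc4)cc32)cc(OC)c1OC`: 450 nM
- Compound 2 `COc1cc(-n2cnc3ccc(-c4ccc(C)cc4F)cc32)cc(OC)c1OC`: 5650 nM
- Compound 3 `COc1cc(-n2cnc3ccc(-c4cccc(N)c4)cc32)cc(OC)c1OC`: 21 nM

In a functional assay on SGC-7901 cells (Homo sapiens) for antiproliferative activity, read by MTT assay, with a stated time of 72 h (on this read-out higher numbers stand for weaker inhibition and lower numbers for stronger inhibition), compound 3 gives the lowest number of the three, and both other compounds stand well clear of it. Compound 4 `COc1cc(-n2cnc3ccc(-c4ccc(F)cc4)cc32)cc(OC)c1OC` has not yet been measured. It differs from compound 3 in one place (4-fluorophenyl in place of 3-aminophenyl on an aromatic carbon): 4-fluorophenyl in place of 3-aminophenyl on an aromatic carbon. All three measured steps change this same group, and all are large: a 21-fold lower number from compound 1 to compound 3 (1.33 log units; beyond the scatter), a 270-fold lower number from compound 2 to compound 3 (2.43 log units; beyond the scatter) and a 13-fold higher number from compound 1 to compound 2 (1.10 log units; beyond the scatter). Within the data shown here, both steps that bring in 3-aminophenyl lower the number, so removing it is expected to raise the number, although no measured compound carries 4-fluorophenyl. A large upward step is therefore expected in this assay, and the estimated step is a 19-fold higher number from compound 3 to compound 4 (1.28 log units; beyond the scatter). For compound 4 the estimated value is 400 nM, with an expected range from 80 nM to 2500 nM.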

Compound 4, half-maximal inhibitory concentration: 3500 nM
For compound 4 the middle estimate is 8.8-fold (0.94 log units) below the measured one, outside the stated range (above it).
By their numbers in this assay, from the lowest: compound 3; then compound 1; then compounds 4 and 2 (each within the scatter of the next).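

In this assay, replacing 3-aminophenyl with 4-fluorophenyl gives a 170-fold higher number from compound 3 to compound 4 (2.22 log units; beyond the scatter), so the low number of compound 3 is not kept by this other substituted phenyl ring. The two fluorine-bearing rings do not separate, with a 1.6-fold lower number from compound 2 to compound 4 (0.21 log units; within the scatter), while the step from the acetyl group to fluoro is a 7.8-fold higher number from compound 1 to compound 4 (0.89 log units; beyond the scatter), which places both fluorine-bearing rings on the weaker side of 4-acetylphenyl. Nothing available here explains these differences.

The step from compound 3 to compound 4 changes both the substituent and its place on the ring, so the compounds shown cannot tell which of the two accounts for the change. A 4-aminophenyl or 3-fluorophenyl group would separate the two, and a 3-hydroxyphenyl group would show whether the amine itself is needed.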